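The compounds below may be only part of what the source reports. "The series", "measured", "known", "first", "only" and "open" are said of these compounds alone.

Going by the values given here, only two compounds have been measured in a functional assay on the whole organism (strain albino) for inhibition, with Rattus norvegicus as the target, read by paw edema, with stated times of 30 min and 1 h, at a dose of 100 mg/kg by the oral route (a higher number here means more inhibition at the dose given (going by the name of the read-out), a lower number less inhibition), and their numbers lie within the scatter of each other. Compound 2 `COc1ccc(C2=NN(C(=O)CBr)C(c3c(Cl)cccc3Cl)C2)cc1OC` gives 48% in this assay. Among the compounds with values here, compound 1 `COc1ccc(C2=NN(C(=O)CBr)C(c3ccco3)C2)cc1OC` gives 38% in this assay, and the single measured step is a number 10 percentage points higher from compound 1 to compound 2 (within the scatter), a change on a saturated ring carbon. Compound 3 `COc1ccc(C2=NN(C(=O)C(C)O[N+](=O)[O-])C(c3c(Cl)cccc3Cl)C2)cc1OC` differs at another place: 1-(nitrooxy)ethyl in place of bromomethyl on a carbonyl carbon. No measured step touches this carbonyl carbon, so nothing shown points to a shift beyond the scatter. Compound 3 is therefore expected to give 48% in this assay, within a range from 30% to 65%. This amounts to an expected step: no change at the digits printed from compound 2 to compound 3 (within the scatter).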

Compound 3, a percentage reported as inhibition, in the whole organism at one dose (the size of the read-out at that dose, not a potency): 47%
The estimate for compound 3 lay 1 percentage points above the measured number; measured number inside the range.
By their numbers in this assay, from the lowest: compounds 1, 3 and 2 (each within the scatter of the next).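

At this carbonyl carbon, which the earlier step did not touch, 1-(nitrooxy)ethyl in place of bromomethyl gives a number 1 percentage points lower from compound 2 to compound 3 (within the scatter) in this assay. The position therefore takes a group with more heavy atoms and with hydrogen-bond acceptors, which bromomethyl lacks, without a shift beyond the scatter. No evidence here bears on why the two groups read alike. Still open, on these data alone, is how an amine or a carboxylic acid would read at this carbonyl carbon, and whether 1-(nitrooxy)ethyl would read the same alongside furan-2-yl.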